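The source may hold more compounds than are shown below. What is called first, only, known or untested is meant among the compounds shown, and "the series" means these compounds.

Measured so far in a functional assay on CHO cells for positive allosteric modulation of metabotropic glutamate receptor 2 (Homo sapiens), read by scintillation counting and GTPgammaS binding, with a stated time of 30 min; on this read-out lower numbers stand for smaller maximal responses and higher numbers for larger maximal responses:
compound 1, `CCCCn1ccc(-c2ccc(Oc3cccnc3C)c(Cl)c2)c(C#N)c1=O`: 236%
compound 2, `Cc1ncccc1Oc1ccc(-c2ccn(CC3CC3)c(=O)c2C#N)cc1Cl`: 180%
compound 3, `CCCCn1ccc(-c2ccc(Oc3ccc(C)nc3C)c(Cl)c2)c(C#N)c1=O`: 231%

Two single changes connect these three. The change cyclopropyl in place of propyl on a saturated chain carbon bound to an aromatic nitrogen gave a number 56 percentage points lower from compound 1 to compound 2 (beyond the scatter). The change methyl in place of hydrogen on an aromatic carbon gave a number 5 percentage points lower from compound 1 to compound 3 (within the scatter), so compound 1 and compound 3 cannot be told apart on this read-out.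

Compound 4, `Cc1ccc(Oc2ccc(-c3ccn(CC4CC4)c(=O)c3C#N)cc2Cl)c(C)n1`, is not yet measured. It differs from compound 3 by cyclopropyl in place of propyl on a saturated chain carbon bound to an aromatic nitrogen, the same change as between compound 1 and compound 2, at the same place. The two cores differ by methyl in place of hydrogen on an aromatic carbon.

The step of a number 56 percentage points lower from compound 3 to compound 4 (beyond the scatter) is expected to be of the same size as the measured one, because the same change gave a number 56 percentage points lower from compound 1 to compound 2 (beyond the scatter). The expectation rests on that single pair only. Compound 4 is thus expected to reach about 175%, most likely between 140% and 210%.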

Compound 4, largest response reached (Emax), in percent of the reference or control that the assay uses: 196%
Compound 4: middle estimate off by 21 percentage points, on the low side; low and high end bracket the measured number.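

In this assay cyclopropyl in place of propyl again lowers the maximal response, with a number 35 percentage points lower from compound 3 to compound 4 (beyond the scatter) and so the direction carries over to the core of compound 3, but the size of the step does not: the same change on two cores in this assay, a number 56 percentage points lower (beyond the scatter) from compound 1 to compound 2 and a number 35 percentage points lower (beyond the scatter) from compound 3 to compound 4, 21 percentage points apart, beyond the scatter of two such steps
Methyl in place of hydrogen on an aromatic carbon also depends on its partner group, with a number 16 percentage points higher from compound 2 to compound 4 (beyond the scatter) set against the earlier step: the same change on two cores in this assay, a number 5 percentage points lower (within the scatter) from compound 1 to compound 3 and a number 16 percentage points higher (beyond the scatter) from compound 2 to compound 4, 21 percentage points apart, beyond the scatter of two such steps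
Among the compounds shown here, these two pairs show only that the two changes do not simply add; they do not explain the gap or predict the step on any further core.

Open, as far as these compounds go, is how a longer chain such as hexyl, or a chain bearing an amine, would behave on the saturated chain carbon bound to an aromatic nitrogen. Also open, from the compounds shown here alone, is whether a methoxy group in place of methyl on the aromatic carbon would follow either step.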